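Replacing 3,4,5-trimethoxyphenyl with thiophen-2-yl on compound 2

The source may report more compounds than this note shows. Statements on the series, on what has been measured and on what is new or still open speak of the compounds shown alone.

Compound 1 `COc1ccc(/C=C/C(=O)/C=C/c2ccc(OCc3cn(CCCOc4cc(=O)oc5ccccc45)nn3)c(OC)c2)cc1`: "not active" (no number reported)
Compound 2 `COc1cc(/C=C/C(=O)/C=C/c2cc(OC)c(OC)c(OC)c2)ccc1OCc1cn(CCCOc2cc(=O)oc3ccccc23)nn1`: 12%

In a functional assay on PC-3 cells (Homo sapiens) for inhibition, read by sulforhodamine B assay, with a stated time of 48 h, tested at 50 uM (a lower number here means less inhibition of growth, a higher number more inhibition of growth at the concentration tested), compound 2 gives 12%, the only number shown, since compound 1 has none. Compound 3 `COc1cc(/C=C/C(=O)/C=C/c2cccs2)ccc1OCc1cn(CCCOc2cc(=O)oc3ccccc23)nn1` carries thiophen-2-yl in place of 3,4,5-trimethoxyphenyl on a double-bonded chain carbon bound to a double-bonded chain carbon. Within the data shown here, no step between measured compounds is available as a guide, so no change beyond the scatter is expected in either direction. The estimated change is a number 3 percentage points higher from compound 2 to compound 3 (within the scatter). For compound 3 the expected value is 15%, with an estimated range of 2% to 35%.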

Compound 3, percent growth inhibition at one concentration: "not active" (no number reported)
No number was reported for compound 3; no gap can be computed for the estimate.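

Among these compounds, compound 3 is reported as not active without a number, so no step between compound 2 and compound 3 can be read. No evidence bears on this result. The compounds shown leave open how far thiophen-2-yl in place of 3,4,5-trimethoxyphenyl shifts the outcome in this assay.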